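Compound 1 and the Loss of Its Methoxy

A few compounds are considered here, and "the series" means these few. Any claim that something is new, unique, unknown or untested is made for them only; others in the source may bear on it.

Compound 1 `COc1ccc(/N=N/N2CCCC2)cc1` - 60000 nM
Compound 2 `Clc1cccc(/N=N/N2CCCCC2)c1` - > 100000 nM

Among the measured compounds shown here, in an ADME assay on MDBK cells (Bos taurus) for cytotoxicity, read by MTT assay, with a stated time of 96 h (a lower number here means that less compound is tolerated, a higher number that more compound is tolerated), compound 1 gives 60000 nM as the only actual number so far. For compound 2 the entry > 100000 nM is a limit of the assay and not a number. Compound 3 `c1ccc(/N=N/N2CCCC2)cc1` is still unmeasured. It differs from compound 1 by a single change hydrogen in place of methoxy on an aromatic carbon with hydrogen in place of methoxy on an aromatic carbon. For the measured compounds named here, no measured pair shows this change. The expectation in this assay is a step within the usual scatter, in no particular direction. The estimated step is a 1.2-fold higher number from compound 1 to compound 3 (0.07 log units; within the scatter) and no more. The estimate for compound 3 is 70000 nM with an expected range from 25000 nM to 100000 nM in this test.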

Compound 3, half-maximal cytotoxic concentration: > 100000 nM
Compound 3: only a limit was reported; the forecaster's own chance of this, stated with the estimate: 30%; middle value at least 1.4-fold (0.15 log units) away from the limit.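

Among the compounds shown here, on the aromatic carbon para to a group of 7 heavy atoms, hydrogen in place of methoxy gives the first direct reading of this change in this assay: an at least 1.6-fold higher number from compound 1 to compound 3 (0.22 log units; that floor lies within the scatter). The methoxy is therefore not needed for the tolerance seen here, although this floor alone does not separate the pair. The entry for compound 3 is a limit and not a number, so the full step stays unknown because the readings stop there: the limit of > 100000 nM in this assay, at which 2 of the 3 values shown sit.

As far as these compounds go, whether an amine or a carboxylic acid on this carbon would bring the number down remains open, as does the effect of a longer chain there.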